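A few compounds are considered here, and "the series" means these few. Any claim that something is new, unique, unknown or untested is made for them only; others in the source may bear on it.

Three compounds carry numbers in a functional assay on 3T3-L1 cells (Mus musculus) for inhibition, with a stated time of 20 min, tested at 20 uM; on this read-out higher numbers stand for more inhibition at the one concentration tested (going by the name of the read-out) and lower numbers for less inhibition. Compound 1 `Cc1ccc(S(=O)(=O)N(Cc2cccc(F)c2F)Cc2cn(S(=O)(=O)c3ccc(C)cc3)c3ccccc23)cc1` gives -13.9%, compound 2 `COc1cc(OC)c(Cn2cc(CN(Cc3cn(S(=O)(=O)c4ccc(C)cc4)c4ccccc34)S(=O)(=O)c3ccc(C)cc3)nn2)c(OC)c1` gives -22%, and compound 3 `COc1ccc(Cn2cc(CN(Cc3cn(S(=O)(=O)c4ccc(C)cc4)c4ccccc34)S(=O)(=O)c3ccc(C)cc3)nn2)c(OC)c1` gives 7.6%. Compound 3 stands highest of the three, beyond the scatter of both compound 1 and compound 2. Going by the values given here, the one step that changes a single place is a number 29.6 percentage points higher from compound 2 to compound 3 (beyond the scatter).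

Compound 4 `Cc1ccc(S(=O)(=O)N(Cc2cn(Cc3ccccc3)nn2)Cc2cn(S(=O)(=O)c3ccc(C)cc3)c3ccccc23)cc1` differs from compound 3 in one place: phenyl in place of 2,4-dimethoxyphenyl on a saturated chain carbon bound to an aromatic nitrogen. The step from compound 2 to compound 3 bears on this change, since it also took away a methoxy group on the same benzyl and raised inhibition in this assay by a modest amount. Compound 1, which carries a different benzyl and no triazole, sits lower than compound 3 and weighs against reading too much into a single step. On balance, compound 4 is expected to sit near compound 3 or somewhat higher, with a step of a number 4.4 percentage points higher from compound 3 to compound 4 (within the scatter). Compound 4 is estimated at 12%, within a range from -12% to 36%.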

Compound 4, a percentage reported as inhibition, at one concentration (the size of the read-out at that concentration, not a potency): 3.4%
Estimate against measurement, compound 4: 8.6 percentage points above, and the stated range covers the measured number.
By their numbers in this assay, from the lowest: compounds 2 and 1 (each within the scatter of the next); then compounds 4 and 3 (each within the scatter of the next).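

In this assay the step of a number 4.2 percentage points lower from compound 3 to compound 4 (within the scatter) means that removing both methoxy groups from the benzyl leaves no reading that separates 2,4-dimethoxyphenyl from phenyl at this position, on a saturated chain carbon bound to an aromatic nitrogen. The step of a number 25.4 percentage points higher from compound 2 to compound 4 (beyond the scatter) stands beside the earlier step from the trimethoxy compound, so among the triazole compounds shown only 2,4,6-trimethoxyphenyl stands apart, while the bare benzyl adds a second comparison with that compound. Going by these compounds alone, the step of a number 17.3 percentage points higher from compound 1 to compound 4 (beyond the scatter) gives the first direct reading of 1-benzyl-1H-1,2,3-triazol-4-yl against 2,3-difluorophenyl on a saturated chain carbon bound to a sulfonamide nitrogen. Nothing measured here accounts for these steps.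

Still open, from the compounds shown here alone, is whether an amine or a carboxylic acid on this phenyl would give a reading beyond the scatter. The same holds for a longer chain in place of the benzyl carbon.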